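This account rests on a few compounds, and the source may have more. Where it says the series, first, only, none or still open, it means among the compounds named here.

In a functional assay on JeKo-1 cells (Homo sapiens) for antiproliferative activity (a lower number here means a stronger inhibitor, a higher number a weaker inhibitor), the series so far reads
- compound 1 `Nc1ncnc2c1c(-c1ccc(Oc3ccccc3)cc1)cn2C[C@H]1CCCN1C[C@@H](O)CO` gives 9540 nM
- compound 2 `Nc1ncnc2c1c(-c1ccc(Oc3ccccc3)cc1)cn2C[C@H]1CCCN1C[C@@H]1CO1` gives 11100 nM

Within the data shown here, compound 2 at 11100 nM stands level with compound 1, the only other measured compound, and the two cannot be separated.

Compound 3 `Nc1ncnc2c1c(-c1ccc(Oc3ccccc3)cc1)cn2[C@H]1CCN(C[C@H]2CO2)C1` carries 1-((oxiran-2-yl)methyl)pyrrolidin-3-yl in place of (1-((oxiran-2-yl)methyl)pyrrolidin-2-yl)methyl on an aromatic nitrogen of the shared core. The counted difference is 1-((oxiran-2-yl)methyl)pyrrolidin-3-yl in place of (1-((oxiran-2-yl)methyl)pyrrolidin-2-yl)methyl on an aromatic nitrogen, and the oxiran-2-yl group itself stays.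

Among the measured compounds shown here, the only measured step is a 1.2-fold higher number from compound 1 to compound 2 (0.07 log units; within the scatter), which swaps 1,2-dihydroxyethyl for oxiran-2-yl. For the measured compounds named here, it leaves the group on the aromatic nitrogen otherwise unchanged, so it bears on the new change only weakly, and no measured step tests that change directly. The data give no direction. In this assay no shift beyond the scatter is therefore expected, and the estimated step is a 1.2-fold lower number from compound 2 to compound 3 (0.09 log units; within the scatter), with wide margins for an untested change. Compound 3 is estimated at 9000 nM, within an expected range of 3000 nM to 25000 nM.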

Compound 3, half-maximal inhibitory concentration: 5080 nM
Compound 3: middle estimate off by 1.8-fold (0.25 log units), on the high side, and the stated range covers the measured number.
By their numbers in this assay, from the lowest: compounds 3, 1 and 2 (each within the scatter of the next, the first and the last beyond it).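

Moving from (1-((oxiran-2-yl)methyl)pyrrolidin-2-yl)methyl to 1-((oxiran-2-yl)methyl)pyrrolidin-3-yl on the aromatic nitrogen gives a 2.2-fold lower number from compound 2 to compound 3 (0.34 log units; beyond the scatter) in this assay; this is the first step in the series to lie beyond the scatter, so the group on this nitrogen can shift the number, whereas the swap of 1,2-dihydroxyethyl for oxiran-2-yl gave no separable change. The comparison with the dihydroxy compound gives a 1.9-fold lower number from compound 1 to compound 3 (0.27 log units; within the scatter), so compound 3 separates from compound 2 but not from compound 1, and the effect of the change is established only against the matched oxiran-2-yl compound. Nothing available on the compounds accounts for the step.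

The change alters the attachment and the ring position together, with 10 heavy atoms leaving and 9 entering, so the share of each in the step remains unresolved. Also open, from the compounds shown here alone, are whether 1-(2,3-dihydroxypropyl)pyrrolidin-3-yl on the aromatic nitrogen would stand level with compound 3, and how a piperidin-3-yl ring or an acrylamide in place of the oxiran-2-ylmethyl group would read in this assay.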